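The source may hold more compounds than are shown below. What is called first, only, known or untested is meant among the compounds shown, and "the series" means these compounds.

Going by the values given here, compound 2 `C[C@@H](NC(=O)c1ccc(C#Cc2ccncc2)cn1)C(C)(C)O` gives 66.6% in a functional assay on HEK293 cells for positive allosteric modulation of metabotropic glutamate receptor 5 (Rattus norvegicus), read by fluorescence and calcium flux (a lower number here means a smaller maximal response, a higher number a larger maximal response), one of two numbers so far. Compound 1 `C[C@@H](NC(=O)c1ccc(C#Cc2cc(F)cc(F)c2)cn1)C(C)(C)O` gives 61.6% in this assay, and the two lie within the scatter of each other. Compound 3 `C[C@@H](NC(=O)c1ccc(C#Cc2cccc(F)n2)cn1)C(C)(C)O` differs from compound 2 by 6-fluoropyridin-2-yl in place of pyridin-4-yl on a triple-bonded carbon. Among the compounds with values here, the only measured step that bears on this change is the exchange of the group on the triple-bonded carbon, and it gave a number 5 percentage points higher from compound 1 to compound 2 (within the scatter). No change beyond the scatter is therefore expected; the estimated step is a number 3.6 percentage points lower from compound 2 to compound 3 (within the scatter). Compound 3 is expected to give 63%, between 50% and 78%.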

Compound 3, largest response reached (reported as efficacy), in percent of the reference or control that the assay uses: 63%
For compound 3 middle estimate and measured number coincide at the digits printed, and the stated range covers the measured number.
By their numbers in this assay, from the lowest: compounds 1, 3 and 2 (each within the scatter of the next).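

In this assay, 6-fluoropyridin-2-yl on the triple-bonded carbon gives a number 3.6 percentage points lower from compound 2 to compound 3 (within the scatter) and also a number 1.4 percentage points higher from compound 1 to compound 3 (within the scatter) in the comparison with 3,5-difluorophenyl. All three aromatic groups at this position thus lie within the scatter of one another, and the fluorinated pyridine ring does not set itself apart from either earlier group. No evidence is available that bears on this result. Still open, on these data alone, is whether a non-aromatic group on the triple-bonded carbon, such as cyclohexyl or a longer alkyl chain, would stay within this range, and whether an amine on the pyridine ring would shift the response.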